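This account rests on a few compounds, and the source may have more. Where it says the series, first, only, none or still open, it means among the compounds named here.

Measured compounds:
- compound 1, `CC(=O)N1N=C(c2ccc(O)cc2)CC1c1ccccc1Cl`: 8.6 nM in an assay on isolated protein for inhibition of Amine oxidase [flavin-containing] A (Homo sapiens); a higher number here means a weaker inhibitor, a lower number a stronger inhibitor
- compound 2, `CC(=O)N1N=C(c2ccc(O)cc2)CC1c1cccc(Cl)c1`: 10 nM
- compound 3, `CC(=O)N1N=C(c2ccc(O)cc2)CC1c1ccc(C)cc1`: 100 nM

Among these three numbers, compound 1 stands lowest. The step of a 1.2-fold higher number from compound 1 to compound 2 (0.07 log units; within the scatter) is within the usual scatter, so compound 1 and compound 2 cannot be told apart. The step of a 12-fold higher number from compound 1 to compound 3 (1.07 log units; beyond the scatter) is beyond it, as is a 10-fold higher number from compound 2 to compound 3 (1.00 log units; beyond the scatter).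

Compound 4, `COc1ccccc1C1CC(c2ccc(O)cc2)=NN1C(C)=O`, is not yet measured. It differs from compound 1 in one place: methoxy in place of chloro on an aromatic carbon. Among the measured compounds shown here, none of the measured steps swaps one group for another at the same aromatic carbon; the two steps from compound 1 change which aryl group sits on the saturated ring carbon, and they show that moving a chloro around the ring changes little, while a 4-methylphenyl costs a lot. Replacing the chloro itself by a methoxy is therefore untested, and only a modest weakening in this assay is expected, with wide uncertainty. For compound 4 the expected step is a 2.3-fold higher number from compound 1 to compound 4 (0.37 log units; beyond the scatter). Compound 4 is therefore estimated at 20 nM, within a range of 5 nM to 80 nM.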

Compound 4, half-maximal inhibitory concentration: 8.8 nM
Compound 4: middle estimate off by 2.3-fold (0.36 log units), on the high side; the measured number falls inside the stated range.
By their numbers in this assay, from the lowest: compounds 1, 4 and 2 (each within the scatter of the next); then compound 3.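

Replacing chloro with methoxy on this aromatic carbon, ortho to a large group, gives a 1.0-fold higher number from compound 1 to compound 4 (0.01 log units; within the scatter) in this assay, so compound 1 and compound 4 cannot be told apart. The earlier steps shown here changed only which aryl group sat on the saturated ring carbon, whereas this one changes the group at a fixed place and shows that a methoxy, which carries a hydrogen-bond acceptor that chloro lacks, is accepted here with no loss beyond the scatter. No available evidence accounts for this match between the two groups.

The compounds shown leave open how far this tolerance extends, for example to an ethoxy, an amine or a carboxylic acid at the same place. On these data alone, it also remains open whether methoxy would match chloro in the 3-chlorophenyl of compound 2.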